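Methoxy for Bromo on a Cell Toxicity Read-out

This account rests on a few compounds, and the source may have more. Where it says the series, first, only, none or still open, it means among the compounds named here.

compound 1 `COc1cccc(-c2cnc(NC(=O)c3ccc(F)cc3)n2C)c1` — > 100000 nM
compound 2 `Cn1c(-c2cccc(Br)c2)cnc1NC(=O)c1ccc(F)cc1` — > 50000 nM
compound 3 `Cn1c(-c2ccccc2Br)cnc1NC(=O)c1ccc(F)cc1` — > 100000 nM

Three compounds sharing one core were run in a toxicity assay on THP-1 cells (Homo sapiens) for inhibition; on this read-out higher numbers stand for lower toxicity in this test and lower numbers for higher toxicity in this test. Compound 1 gives > 100000 nM, which is a limit of the test and not a number. Compound 2 gives > 50000 nM, likewise a limit. Compound 3 gives > 100000 nM, again a limit. Two of the three values sit at the limit of > 100000 nM in this assay, at which 2 of the 3 values shown sit, and one at the limit of > 50000 nM in this assay, at which 1 of the 3 values shown sits, so every comparison among them rests on limits alone.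

The change methoxy in place of bromo on an aromatic carbon gives the step that the two limits leave unreadable from compound 2 to compound 1. The two cores differ in the change (2-bromophenyl in place of 3-bromophenyl on an aromatic carbon), with the step that the two limits leave unreadable from compound 2 to compound 3. The step that the two limits leave unreadable from compound 1 to compound 3 is likewise unreadable.

Compound 4 `COc1ccccc1-c1cnc(NC(=O)c2ccc(F)cc2)n1C` has not been measured. It arises from compound 3 by the change (methoxy in place of bromo on an aromatic carbon). This is the same kind of change as that from compound 2 to compound 1, but the place is not the same: here the group sits ortho to a large group, there it sat meta to a large group. The step of a number no higher from compound 3 to compound 4 (the limit leaves the size open) is expected to be small, because a step that the two limits leave unreadable from compound 2 to compound 1 showed nothing readable and all three measured values rest at limits such as the limit of > 100000 nM in this assay, at which 2 of the 3 values shown sit. Compound 4 is therefore estimated at 100000 nM, expected to lie between 50000 nM and 200000 nM, most likely again reported only as a limit.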

Compound 4, half-maximal cytotoxic concentration: > 100000 nM
Compound 4: no number, only a limit; the forecaster's own chance of this, stated with the estimate: 85%; the middle value sits exactly at the limit.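

In this assay compound 4 gives > 100000 nM, which is a limit of the test and not a number. None of the steps to compound 4 from compound 1, compound 2 or compound 3 can be read. The compounds shown leave open what toxicity values any of the four would have as numbers, and whether methoxy in place of bromo shifts this read-out at either place.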